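One Inverted Stereocentre in a Cytotoxic Series

This account rests on a few compounds, and the source may have more. Where it says the series, first, only, none or still open, it means among the compounds named here.

In a functional assay on KB cells (Homo sapiens) for cytotoxicity (on this read-out lower numbers stand for stronger inhibition and higher numbers for weaker inhibition), compound 1 `CCCCCCCCCCCCCC[C@H]1N[C@H](CO)[C@H]1O` gives 6 ug/mL and compound 2 `CCCCCCCCCCCCCC[C@@H]1N[C@@H](CO)[C@@H]1O` gives 3.4 ug/mL, which places the two within the scatter of each other. Compound 3 `CCCCCCCCCCCCCC[C@@H]1N[C@H](CO)[C@@H]1O` departs from compound 2 by the two compounds have the same atoms and bonds and differ only in configuration as drawn: 1 of 3 stereo elements differ; a stereocentre at a saturated ring carbon is drawn S in compound 2 and R in compound 3. For the measured compounds named here, the only measured step bearing on this change is a 1.8-fold lower number from compound 1 to compound 2 (0.25 log units; within the scatter), which inverts all stereocentres and rests on (the fact that compounds 1 and 2 differ only in the configuration as drawn). With that full inversion staying within the scatter, no step beyond the scatter is expected in this assay, and the expected step is a 1.2-fold higher number from compound 2 to compound 3 (0.07 log units; within the scatter). For compound 3 the estimated value is 4 ug/mL, with an expected range of 1.5 ug/mL to 10 ug/mL.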

Compound 3, half-maximal inhibitory concentration: > 10 ug/mL
Compound 3: no number, only a limit; the forecaster's own chance of this, stated with the estimate: 5%; middle value at least 2.5-fold (0.39 log units) from the limit.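

Compound 3 gives only a limit in this assay, > 10 ug/mL, not a number. Whereas the full inversion separating compounds 1 and 2 stayed within the scatter, inverting this one saturated ring carbon gives an at least 2.9-fold higher number from compound 2 to compound 3 (0.46 log units; beyond the scatter), so a single stereocentre can count for more than all three together, and nothing else separates the pair: the fact that compounds 2 and 3 differ only in the configuration as drawn The comparison with the mirror-image partner is less firm, since an at least 1.6-fold higher number from compound 1 to compound 3 (0.22 log units; that floor lies within the scatter) gives only a floor.

From the compounds shown here alone, how far compound 3 lies past its limit stays open. So does whether a shorter chain or a carboxylic acid on the shared core would respond to this inversion in the same way.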